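Estimating a Nitrophenyl Hydrazone Analogue of Compound 1

A few compounds are considered here, and "the series" means these few. Any claim that something is new, unique, unknown or untested is made for them only; others in the source may bear on it.

Measured compounds:
compound 1 `CCOC(=O)C1=C(N/C=N/c2cccnc2Cl)Nc2[nH]nc(C)c2C1c1ccc(N(C)C)cc1`: 4630 nM
compound 2 `CCOC(=O)C1=C(N/C=N/c2ccc([N+](=O)[O-])cc2)Nc2[nH]nc(C)c2C1c1ccc(N(C)C)cc1`: 57800 nM
compound 3 `CCOC(=O)C1=C(N/N=C(/Cl)C#N)Nc2[nH]nc(C)c2C1c1ccc(N(C)C)cc1`: 26200 nM

In a functional assay on HeLa cells (Homo sapiens) for inhibition, read by MTT assay, with a stated time of 48 h (on this read-out lower numbers stand for stronger inhibition and higher numbers for weaker inhibition), compound 1 gives 4630 nM, the lowest of the three numbers; the nearest is compound 3 and the furthest is compound 2, both beyond the scatter. Compound 4 `CCOC(=O)C1=C(N/N=C(/Cl)c2ccc([N+](=O)[O-])cc2)Nc2[nH]nc(C)c2C1c1ccc(N(C)C)cc1` has not been measured. It differs from compound 1 in one place: a group of 12 heavy atoms (7 carbon, 2 nitrogen, 2 oxygen, 1 chlorine; one six-membered aromatic ring of carbon only) in place of a group of 9 heavy atoms (6 carbon, 2 nitrogen, 1 chlorine; one six-membered aromatic ring with 1 hetero atom), on an amine nitrogen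

Within the data shown here, two measured steps bear on this change. Putting a 4-nitrophenyl group onto the double-bonded nitrogen gave a 12-fold higher number from compound 1 to compound 2 (1.10 log units; beyond the scatter). Replacing the whole chloropyridinyl group with the small chloro-nitrile hydrazone gave a 5.7-fold higher number from compound 1 to compound 3 (0.75 log units; beyond the scatter). Compound 4 carries both the hydrazone-type linkage of compound 3 and the nitrophenyl group of compound 2, so a higher number than compound 1 is expected in this assay, of a size comparable to those two steps. The estimated step is a 6.5-fold higher number from compound 1 to compound 4 (0.81 log units; beyond the scatter). Compound 4 is therefore expected to give about 30000 nM, with a likely range from 8000 nM to 120000 nM.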

Compound 4, half-maximal inhibitory concentration: 46200 nM
For compound 4 the middle estimate is 1.5-fold (0.19 log units) below the measured one, and the stated range covers the measured number.
By their numbers in this assay, from the lowest: compound 1; then compounds 3, 4 and 2 (each within the scatter of the next, the first and the last beyond it).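

At the amine nitrogen, the group of compound 4 gives a 10-fold higher number from compound 1 to compound 4 (1.00 log units; beyond the scatter), so joining the linkage of compound 3 to the 4-nitrophenyl group of compound 2 does not restore the low number of compound 1. Placing 4-nitrophenyl in place of cyano on the carbon with a double bond to nitrogen gives a 1.8-fold higher number from compound 3 to compound 4 (0.25 log units; within the scatter), and moving from the group of compound 2 to that of compound 4 gives a 1.3-fold lower number from compound 2 to compound 4 (0.10 log units; within the scatter), which leaves compound 1 as the only one of the compounds shown beyond the scatter of compound 4. Nothing measured alongside these numbers accounts for them.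

The compounds shown leave open whether the low number of compound 1 rests on the ring nitrogen of its 2-chloropyridin-3-yl group, on its chlorine or on its linkage. They also leave open how an amine or a carboxylic acid in place of the nitro of the 4-nitrophenyl group would read in this assay.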